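This account rests on a few compounds, and the source may have more. Where it says the series, first, only, none or still open, it means among the compounds named here.

Compound 2 `CC(C(=O)NCc1ccc(C(F)(F)F)nc1C1CC2CCC1C2)c1ccc(NS(C)(=O)=O)c(F)c1` gives 1.5 nM in an assay on CHO cells for antagonist activity at transient receptor potential cation channel subfamily V member 1 (Homo sapiens), read by FLIPR and calcium flux (a lower number here means a stronger inhibitor, a higher number a weaker inhibitor), level with compound 1 `CC(C(=O)NCc1ccc(C(F)(F)F)nc1C1CCC(F)(F)CC1)c1ccc(NS(C)(=O)=O)c(F)c1`, which gives 1.5 nM in this assay. Compound 3 `CC(C(=O)NCc1ccc(C(F)(F)F)nc1C1=C[C@H](C)CCC1)c1ccc(NS(C)(=O)=O)c(F)c1` differs from compound 2 in one place: a group of 7 heavy atoms (7 carbon; one six-membered non-aromatic ring of carbon only) in place of a group of 7 heavy atoms (7 carbon; 2 five-membered non-aromatic rings of carbon only), on an aromatic carbon. Going by the values given here, the only measured step at this position, no change at the digits printed from compound 1 to compound 2 (within the scatter), shows that one carbon ring standing in for another there left the result unchanged. A further swap of carbon rings at the same spot is therefore expected to move the value little, if at all: a 1.7-fold higher number from compound 2 to compound 3 (0.22 log units; within the scatter). Compound 3 is estimated to give 2.5 nM in this assay, most likely between 0.8 nM and 8 nM.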

Compound 3, inhibition constant: 0.1 nM
Beside the measured number, compound 3's estimate is 25-fold (1.40 log units) above it, and the stated range ends above it.
By their numbers in this assay, from the lowest: compound 3; then compounds 1 and 2 (each within the scatter of the next).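

In this assay, carbon rings at this position are not interchangeable: with the heavy-atom count unchanged and all carbon, 3-methylcyclohex-1-en-1-yl gives a 15-fold lower number from compound 2 to compound 3 (1.18 log units; beyond the scatter) in place of the bridged group. Set against 4,4-difluorocyclohexyl, it gives a 15-fold lower number from compound 1 to compound 3 (1.18 log units; beyond the scatter), so the level shared by the two earlier compounds was not the lowest reachable here. No measurement shown explains this gain.

The compounds shown do not separate the double bond, the methyl group and the defined stereocentre as the source of the step. As far as these compounds go, how a piperidine ring would fare at this spot also remains open.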